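The source may hold more compounds than are shown below. What is called first, only, known or untested is meant among the compounds shown, and "the series" means these compounds.

Working notes on the series, read in a functional assay on brain (Rattus norvegicus, strain Wistar) for inhibition; on this read-out higher numbers stand for weaker inhibition and lower numbers for stronger inhibition. Compound 1 `Cc1[nH]c(=O)n(C)c1-c1ccccc1` gives > 100000 nM, which is a limit and not a number. Compound 2 `CCCCn1c(-c2ccccc2)c(C)[nH]c1=O` gives > 100000 nM, which is also a limit. Compound 2 therefore has no number of its own, and its standing is given only by the limit of > 100000 nM in this assay, at which 2 of the 3 values shown sit. Among the compounds with values here, compound 3 `CCCCc1ccc(-c2c(C)[nH]c(=O)n2CCCC)cc1` gives 12000 nM, the only actual number so far in this assay.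

The next change leads to compound 4 `Cc1[nH]c(=O)n(C2CCCCC2)c1-c1ccccc1`, with cyclohexyl in place of butyl on an aromatic nitrogen. Within the data shown here, two measured steps bear on it. The first, a step that the two limits leave unreadable from compound 1 to compound 2, also changes the group on an aromatic nitrogen, but its size cannot be read. The second, an at least 8.3-fold lower number from compound 2 to compound 3 (0.92 log units; beyond the scatter), is the only readable gain, and it comes from a butyl on an aromatic carbon, which compound 4 does not carry. No step beyond the scatter is therefore expected with any confidence, and a reading that again stops at the limit is the likeliest outcome. The expected step is a number no higher from compound 2 to compound 4 (the limit leaves the size open). For compound 4 the estimated value is 100000 nM, with an expected range from 30000 nM to 300000 nM.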

Compound 4, half-maximal inhibitory concentration: 47600 nM
Beside the measured number, compound 4's estimate is 2.1-fold (0.32 log units) above it; low and high end bracket the measured number.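

On an aromatic nitrogen of the shared core, cyclohexyl in place of butyl gives the first readable gain at this position in this assay, an at least 2.1-fold lower number from compound 2 to compound 4 (0.32 log units; beyond the scatter). Cyclohexyl in place of methyl at the same position gives an at least 2.1-fold lower number from compound 1 to compound 4 (0.32 log units; beyond the scatter), so of the three groups shown on this nitrogen, only cyclohexyl brings a compound without a butyl on an aromatic carbon to an actual number. The true size of both steps stays open because compound 1 and compound 2 carry limits and not numbers: the limit of > 100000 nM in this assay, at which 2 of the 4 values shown sit.

On these data alone, whether the gain follows the six-membered ring or the count of six carbons remains open, and a hexyl chain or a cyclopentyl group on the same nitrogen would separate the two readings. Also open, as far as these compounds go, is whether cyclohexyl on this nitrogen and the butyl on an aromatic carbon seen in compound 3 would add up when carried together on the shared core.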